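The source may report more compounds than this note shows. Statements on the series, on what has been measured and on what is new or still open speak of the compounds shown alone.

Three compounds have been measured in an ADME assay on microsomes from liver (Homo sapiens) for metabolic stability; on this read-out lower numbers stand for a shorter-lived compound and higher numbers for a longer-lived compound:

Compound 1 `O=C1COc2cc(Nc3cc4c(cn3)ncn4CC3CC3)ccc2N1`: > 1.66 h (a limit)
Compound 2 `CN1C(=O)CCc2cc(Nc3cc4c(cn3)ncn4CC3CC3)ccc21`: 1.17 h
Compound 3 `CN1C(=O)COc2cc(Nc3cc4c(cn3)ncn4CC3CC3)cnc21`: > 1.66 h (a limit)

Compound 3 stands at > 1.66 h, which is a limit of the assay and not a number. For compound 3, this is the limit of > 1.66 h in this assay, at which 2 of the 3 values shown sit. Its true half-life is therefore not known, and any step away from it can only be judged loosely.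

The next compound, compound 4 `Cc1nc(Nc2cnc3c(c2)OCC(=O)N3C)cc2c1ncn2CC1CC1`, keeps compound 3 unchanged except at one place: methyl in place of hydrogen on an aromatic carbon, next to the ring nitrogen (methyl in place of hydrogen on an aromatic carbon).

Among the compounds with values here, no pair of measured compounds differs in only one place, so the data give no direct guide to what this change does. Within the data shown here, compound 2, at 1.17 h, is the only compound with a full number, and it offers a rough idea of the values to expect in this family.

The expected change is modest: an at least 1.0-fold lower number from compound 3 to compound 4 (0.01 log units; that floor lies within the scatter) is estimated to stay within the usual scatter, with any shift more likely towards a shorter half-life. For compound 4 the estimated half-life in this assay is 1.6 h, with an expected range of 0.8 h to 2.6 h.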

Compound 4, half-life: > 1.66 h
Compound 4 ended at the assay's limit (the forecaster's own chance of this, stated with the estimate: 50%); middle value at least 1.0-fold (0.01 log units) away from the limit.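

Compound 4 gives > 1.66 h in this assay, which is a limit of the assay and not a number. Within the data shown here, compound 3 also stands at a limit, so no step between compound 3 and compound 4 can be read: the limit of > 1.66 h in this assay, at which 3 of the 4 values shown sit. The compounds shown leave open whether methyl in place of hydrogen on an aromatic carbon changes the half-life at all, and how long either compound truly lasts.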